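Cyclobutyl for butyl on the chain at the ring nitrogen

A few compounds are considered here, and "the series" means these few. Any claim that something is new, unique, unknown or untested is made for them only; others in the source may bear on it.

Measured in a functional assay on MCF7 cells (Homo sapiens) for antiproliferative activity; a higher number here means a weaker inhibitor, a lower number a stronger inhibitor:
compound 1 `CCCCCn1c(Cc2cc(OC)c(OC)c(OC)c2)nc2c(N)nc(F)nc21` gives 36300 nM
compound 2 `CCCCCn1c(Cc2cc(OC)c(OC)c(OC)c2)nc2c(N)ncnc21` gives 61700 nM
compound 3 `CCCCn1c(Cc2cc(OC)c(OC)c(OC)c2Br)nc2c(N)ncnc21` gives 25100 nM

Compound 2 stands highest of the three numbers in this assay; its nearest neighbour is compound 1, at a 1.7-fold higher number from compound 1 to compound 2 (0.23 log units; within the scatter), a gap within the scatter, and the widest gap is to compound 3, beyond the scatter. Compound 4 `COc1cc(Cc2nc3c(N)ncnc3n2CC2CCC2)cc(OC)c1OC` is not yet measured. It differs from compound 2 by cyclobutyl in place of butyl on a saturated chain carbon bound to an aromatic nitrogen. Within the data shown here, no measured step touches this position: the only single-point step, from compound 1 to compound 2, changes fluoro to hydrogen on an aromatic carbon, and compound 3 differs from compound 2 in two places. Among the measured compounds shown here, with no step to lean on, no change beyond the scatter is expected in this assay, so the step from compound 2 to compound 4 is estimated as a 1.2-fold lower number from compound 2 to compound 4 (0.09 log units; within the scatter). Compound 4 is therefore expected to give about 50000 nM in this assay, with a likely range from 20000 nM to 150000 nM.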

Compound 4, half-maximal inhibitory concentration: 45700 nM
Beside the measured number, compound 4's estimate is 1.1-fold (0.04 log units) above it; measured number inside the range.
By their numbers in this assay, from the lowest: compounds 3, 1, 4 and 2 (each within the scatter of the next, the first and the last beyond it).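

Among these compounds, this is the first reading at this position: in this assay cyclobutyl in place of butyl gives a 1.4-fold lower number from compound 2 to compound 4 (0.13 log units; within the scatter) and keeps the count of four carbons while adding a four-membered ring. Read one bond further out, pentyl to cyclobutylmethyl is thus accepted on the shared core with no change beyond the scatter. Nothing available accounts for this result.

From the compounds shown here alone, whether a cyclohexyl ring, a longer chain or an amine on this chain would shift the number remains open. Also open, going by these compounds, is whether cyclobutyl behaves the same alongside the fluoro of compound 1.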